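What One Pyridine Swap May Do to Compound 3

A few compounds are considered here, and "the series" means these few. Any claim that something is new, unique, unknown or untested is made for them only; others in the source may bear on it.

In a physicochemical assay for lipophilicity, read by LC-MS, in phosphate buffer, measured as octanol-water partition, with a stated time of 30 min, at pH 7.4, tested at 200 mM (a higher number here means a more lipophilic compound, a lower number a more polar compound), compound 2 (`Cn1c(COc2cccc(C(=O)O)c2)nc2ccc(Oc3ncccc3F)cc21`) reads 0.6 and compound 1 (`Cc1ccnc(Oc2ccc3nc(COc4cccc(C(=O)O)c4)n(C)c3c2)c1`) reads 0.8 so the two lie within the scatter of each other. The next structure is compound 3 (`Cc1ccc(C)c(Oc2ccc3nc(COc4cccc(C(=O)O)c4)n(C)c3c2)n1`), which has 3,6-dimethylpyridin-2-yl in place of 3-fluoropyridin-2-yl on an oxygen on an aromatic ring. For the measured compounds named here, only one measured step bears on this change. It is a number 0.20 log units lower from compound 1 to compound 2 (within the scatter) and it puts 3-fluoropyridin-2-yl in place of 4-methylpyridin-2-yl. Read in reverse, that small step offers a weak hint of an upward move, and no measured compound carries 3,6-dimethylpyridin-2-yl. On that slim evidence the expected change is upward, a number 0.40 log units higher from compound 2 to compound 3 (beyond the scatter) with wide uncertainty. In this assay the estimated value for compound 3 is 1 (expected range 0.6 to 1.4).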

Compound 3, distribution coefficient: 1.4
Estimate against measurement, compound 3: 0.40 log units below; measured number inside the range.
By their numbers in this assay, from the lowest: compounds 2 and 1 (each within the scatter of the next); then compound 3.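

Before compound 3, the only step at this position lay within the scatter, so the group on this oxygen had shown no clear effect on the number in this assay. The new group changes that, giving a number 0.80 log units higher from compound 2 to compound 3 (beyond the scatter) and a number 0.60 log units higher from compound 1 to compound 3 (beyond the scatter), which shows that the reading can respond to the group at this place and that 3,6-dimethylpyridin-2-yl stands apart from both earlier groups. Nothing measured here explains this rise.

Going by these compounds, the two methyl groups of 3,6-dimethylpyridin-2-yl enter together, so the share of each stays unknown. Whether an amine or a longer chain on this oxygen would move the number also remains open, as every group shown at this place is a substituted pyridine.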